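Amide variants: rat paw edema inhibition, next step

The compounds below may be only part of what the source reports. "The series", "measured", "known", "first", "only" and "open" are said of these compounds alone.

Measured so far in a functional assay on the whole organism (strain Wistar) for inhibition, with Rattus norvegicus as the target, read by paw edema, with stated times of 30 min and 0.5 h, at a dose of 20 mg/kg; on this read-out lower numbers stand for less inhibition and higher numbers for more inhibition at the one dose given (going by the name of the read-out):
compound 1 `CCOC(=O)C1=C(C)NC(C)=C(C(=O)OCC)C1c1ccc(OCC(=O)Nc2c(C)cccc2C)cc1`: 15.9%
compound 2 `CCOC(=O)C1=C(C)NC(C)=C(C(=O)OCC)C1c1ccc(OCC(=O)Nc2nc3ccccc3s2)cc1`: 47.7%
compound 3 `CCOC(=O)C1=C(C)NC(C)=C(C(=O)OCC)C1c1ccc(OCC(=O)NNC(=O)c2cccs2)cc1`: 44%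

Compound 3 stands second highest of the three numbers. The gap to its nearest neighbour, a number 3.7 percentage points lower from compound 2 to compound 3 (within the scatter), lies within the scatter; the gap to the furthest, a number 28.1 percentage points higher from compound 1 to compound 3 (beyond the scatter), lies beyond it.

Compound 4 `CCOC(=O)C1=C(C)NC(C)=C(C(=O)OCC)C1c1ccc(OCC(=O)NNC(=O)c2ccsc2Cl)cc1` differs from compound 3 in one place: 2-chlorothiophen-3-yl in place of thiophen-2-yl on a carbonyl carbon. Among the measured compounds shown here, all three measured steps, a number 31.8 percentage points higher from compound 1 to compound 2 (beyond the scatter), a number 28.1 percentage points higher from compound 1 to compound 3 (beyond the scatter) and a number 3.7 percentage points lower from compound 2 to compound 3 (within the scatter), alter the group on the amide-type nitrogen; none touches the group on the carbonyl carbon, so no measured step bears on this change. In this assay no step beyond the scatter is therefore expected. Compound 4 is estimated at 44%, in the range 30% to 58%. The expected step is no change at the digits printed from compound 3 to compound 4 (within the scatter).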

Compound 4, a percentage reported as inhibition, in the whole organism at one dose (the size of the read-out at that dose, not a potency): 12.9%
Beside the measured number, compound 4's estimate is 31.1 percentage points above it; the measured number lies below the stated range.
By their numbers in this assay, from the lowest: compounds 4 and 1 (each within the scatter of the next); then compounds 3 and 2 (each within the scatter of the next).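

In this assay, among the compounds shown here, the group on the carbonyl carbon proves decisive, a place the earlier compounds left unchanged: the step with 2-chlorothiophen-3-yl in place of thiophen-2-yl is a number 31.1 percentage points lower from compound 3 to compound 4 (beyond the scatter). The other two readings are a number 34.8 percentage points lower from compound 2 to compound 4 (beyond the scatter) and a number 3 percentage points lower from compound 1 to compound 4 (within the scatter), so this one change cancels the gain held by the thiophen-2-yl hydrazide. No measurement at hand accounts for this loss.

The chlorine and the ring attachment change together here, so their shares stay unresolved. Thiophen-3-yl and 5-chlorothiophen-2-yl on the same carbonyl carbon would separate them.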